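Trifluoromethyl for Chloro in a Weakly Active Series

The compounds below may be only part of what the source reports. "The series", "measured", "known", "first", "only" and "open" are said of these compounds alone.

Measured compounds:
Compound 1, `Cc1nc(C(=O)N2CCC3(CC3)C[C@H]2CNc2ccc(C(F)(F)F)cn2)c(-c2ccccc2)s1`: < 5
Compound 2, `Cc1nc(C(=O)N2CCC3(CC3)C[C@H]2CNc2ccc(Cl)cn2)c(-c2ccccc2)s1`: < 5
Compound 3, `Cc1ccc(-c2ncccn2)c(C(=O)N2CC3(CC3)C[C@H]2CNc2ccc(Cl)cn2)c1`: < 5

All three were tested in a functional assay on HEK293 cells for antagonist activity at Orexin receptor type 2 (Homo sapiens), read by FLIPR and calcium flux; on this read-out higher numbers stand for higher potency (the scale is a negative logarithm) and lower numbers for lower potency. Compound 1 gives only a limit of the assay, < 5. Compound 2 likewise gives only a limit, < 5. Compound 3 also gives only a limit, < 5. In short, (the limit of < 5 in this assay, at which 3 of the 3 values shown sit).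

Compound 1 and compound 2 share a core and differ in one place: trifluoromethyl in place of chloro on an aromatic carbon. The step this made, a step that the two limits leave unreadable from compound 2 to compound 1, cannot be sized, since both values are limits. The difference between the core of compound 2 and the core of compound 3 is not broken down here.

Compound 4, `Cc1ccc(-c2ncccn2)c(C(=O)N2CC3(CC3)C[C@H]2CNc2ccc(C(F)(F)F)cn2)c1`, remains to be measured in this assay . It differs from compound 3 by trifluoromethyl in place of chloro on an aromatic carbon, the same change that separates compound 2 and compound 1, at the same place on the ring.

The earlier instance of this change left no readable step, and compound 3 itself sits at the limit. Compound 4 is therefore expected to stay near that limit as well, with an estimated value of 4.7, lying between 4 and 5.4. The step expected from compound 3 to compound 4 is a step that the limit leaves unreadable from compound 3 to compound 4, resting on the unreadable earlier step and the limit shown by compound 3.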

Compound 4, negative logarithm of the antagonist equilibrium constant: 6.6
Compound 4: middle estimate off by 1.90 log units, on the low side, and the stated range ends below it.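

In this assay, the change from 5-chloropyridin-2-yl to 5-(trifluoromethyl)pyridin-2-yl gave a number at least 1.60 log units higher from compound 3 to compound 4 (beyond the scatter), so on this core the change is tied to a clear gain, and compound 4 is the only compound shown whose value is a number rather than a limit. The same change on the other core cannot be read, and that reading leaves it undecided whether the gain was absent there or merely hidden, since the values on both sides of that step are limits: the limit of < 5 in this assay, at which 3 of the 4 values shown sit. For the compounds shown here, the result therefore shows that the change can matter a great deal on one core, but with only one readable instance it does not show that the gain carries from one core to another, nor does it tie the gain to any feature of either core.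

Going by these compounds, whether a smaller or differently built group, such as a nitrile or a methoxy group, would hold the value of compound 4, 6.6, in the place of the trifluoromethyl stays open. On these data alone, it also stays open how far the gain would reach on any further core.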